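This account rests on a few compounds, and the source may have more. Where it says the series, first, only, none or still open, it means among the compounds named here.

So far, two compounds sharing one core have been measured in a functional assay on A549 cells (Homo sapiens) for cytotoxicity, read by MTT assay, with a stated time of 72 h; on this read-out higher numbers stand for weaker inhibition and lower numbers for stronger inhibition. Compound 1 `COc1ncc(-c2ccc3nc(NC(=O)NCCN4CCCC4)nn3c2)cc1NS(=O)(=O)c1ccc(F)cc1` gives 960 nM. Compound 2 `CCCNC(=O)Nc1nc2ccc(-c3cnc(OC)c(NS(=O)(=O)c4ccc(F)cc4)c3)cn2n1` gives 220 nM, the lower of the two numbers and so the stronger inhibition. For the measured compounds named here, the one measured step, a 4.4-fold lower number from compound 1 to compound 2 (0.64 log units; beyond the scatter), is modest and replaces pyrrolidin-1-yl with methyl on the same chain.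

Compound 3 `COc1ncc(-c2ccc3nc(NC(=O)NCC(=O)N4CCOCC4)nn3c2)cc1NS(=O)(=O)c1ccc(F)cc1` alters that chain again: (morpholin-4-yl)carbonyl in place of ethyl on a saturated chain carbon bound to an amide-type nitrogen. Here (morpholin-4-yl)carbonyl stands in place of ethyl on a saturated chain carbon bound to an amide-type nitrogen, so propyl becomes ((morpholin-4-yl)carbonyl)methyl.

Going by the values given here, only that one step bears on this change. Compound 1, whose chain also ends in a non-aromatic ring, sits at 960 nM, which leans toward a higher number for compound 3. Among the compounds with values here, this is thin evidence, since it is a single comparison and the carbonyl has no counterpart in compound 1. The step expected in this assay is a 3.0-fold higher number from compound 2 to compound 3 (0.47 log units; beyond the scatter), modest and towards weaker inhibition. The estimated value for compound 3 is 650 nM, with an expected range of 220 nM to 1900 nM.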

Compound 3, half-maximal inhibitory concentration: 2570 nM
Compound 3: the middle estimate sits 4.0-fold (0.60 log units) below what was measured; the measured number lies above the stated range.
By their numbers in this assay, from the lowest: compound 2; then compound 1; then compound 3.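

In this assay, the swap at this saturated chain carbon bound to an amide-type nitrogen can cost much more than the earlier step suggested: (morpholin-4-yl)carbonyl in place of ethyl gives a 12-fold higher number from compound 2 to compound 3 (1.07 log units; beyond the scatter) and is the largest step seen so far. The two chains that end in a non-aromatic ring also do not behave alike, since (morpholin-4-yl)carbonyl in place of (pyrrolidin-1-yl)methyl gives a 2.7-fold higher number from compound 1 to compound 3 (0.43 log units; beyond the scatter) and so the result depends on which ring-bearing group enters, not merely on a ring being present. Among these three compounds, the plain propyl chain of compound 2 gives the lowest number, but nothing measured here explains why the chains rank in this order.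

The carbonyl and the morpholine ring enter together in compound 3, so the compounds shown cannot say which of the two goes with the higher number; a dimethylcarbamoyl group at the same place would separate them. From the compounds shown here alone, how a longer chain such as butyl, an open-chain amine such as dimethylamino or a carboxylic acid would fare at this place also remains open.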